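Fixing one stereocentre in compound 3

This account rests on a few compounds, and the source may have more. Where it says the series, first, only, none or still open, it means among the compounds named here.

In an in vivo ADME assay on the whole organism (strain Sprague-Dawley) for pharmacokinetics, with Rattus norvegicus as the target (on this read-out higher numbers stand for wider distribution into tissues and lower numbers for narrower distribution), compound 3 `O=C1[C@@H](NS(=O)(=O)c2ccc3cc(Cl)ccc3c2)CCN1c1ccc(C2CCCN2)cc1F` gives 1.9 L/kg. Compound 1 `CN[C@@H](C)c1ccc(N2CC[C@H](NS(=O)(=O)c3ccc4cc(Cl)ccc4c3)C2=O)c(F)c1` gives 2.4 L/kg, within the scatter of compound 3. Compound 2 `O=C1[C@@H](NS(=O)(=O)/C=C/c2ccc(Cl)s2)CCN1c1ccc(C2CCCN2)cc1F` gives 0.7 L/kg. Compound 3 therefore stands level with compound 1 and beyond the scatter above compound 2.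

Compound 4 `O=C1[C@@H](NS(=O)(=O)c2ccc3cc(Cl)ccc3c2)CCN1c1ccc([C@H]2CCCN2)cc1F` has the same atoms and bonds as compound 3: the two compounds have the same atoms and bonds; at least one stereo element is drawn with a configuration in one of them and without one in the other: 1 of 2 stereo elements differ; a stereocentre at a saturated ring carbon is drawn without a configuration in compound 3 and R in compound 4. A stereocentre at a saturated ring carbon is drawn without a configuration in compound 3 and R in compound 4.

Among the compounds with values here, no measured step changes a configuration alone. The closest is a 1.3-fold lower number from compound 1 to compound 3 (0.10 log units; within the scatter), with pyrrolidin-2-yl in place of 1-(methylamino)ethyl on an aromatic carbon. The other is a 2.7-fold higher number from compound 2 to compound 3 (0.43 log units; beyond the scatter), a modest step with 6-chloronaphthalen-2-yl in place of 2-(5-chlorothiophen-2-yl)ethenyl on a sulfonyl sulfur, and it concerns a different place in the structure.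

No step beyond the scatter is expected in this assay, and the estimate is a 1.1-fold higher number from compound 3 to compound 4 (0.02 log units; within the scatter). For compound 4 the estimated value is 2 L/kg, with an expected range of 1.1 L/kg to 3.6 L/kg.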

Compound 4, volume of distribution at steady state: 1.9 L/kg
The estimate for compound 4 lay 1.1-fold (0.02 log units) above the measured number; the measured number falls inside the stated range.
By their numbers in this assay, from the lowest: compound 2; then compounds 3, 4 and 1 (each within the scatter of the next).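

In this assay, within the data shown here, setting the saturated ring carbon of the pyrrolidin-2-yl group to R shows no shift at this position (no change at the digits printed from compound 3 to compound 4 (within the scatter)), the first reading at this stereocentre. The compound with the defined centre also stands level with the open-chain 1-(methylamino)ethyl compound (a 1.3-fold lower number from compound 1 to compound 4 (0.10 log units; within the scatter)), so the comparison made with compound 3 holds once the configuration is drawn. What this step can be taken to compare rests on how the two structures are drawn: the fact that one of compounds 3 and 4 is drawn with a defined configuration and the other without, at the place where they differ.

Open, as far as these compounds go, is whether the S configuration at this carbon, or a piperidin-2-yl group in place of pyrrolidin-2-yl, would stay at this level. Also open, from the compounds shown here alone, is whether the R centre would read the same alongside the 2-(5-chlorothiophen-2-yl)ethenyl group of compound 2.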